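The source may hold more compounds than are shown below. What is called first, only, known or untested is meant among the compounds shown, and "the series" means these compounds.

Measured compounds:
compound 1, `CN(C(=O)NC(=O)c1ccc(Cl)cc1Cl)c1nc(C(F)(F)F)c(C(=O)N/N=C/c2cccc(C(F)(F)F)c2)s1`: 9.6 ug/mL
compound 2, `CN(C(=O)NC(=O)c1ccc(Cl)cc1Cl)c1nc(C(F)(F)F)c(C(=O)N/N=C/c2ccc(C(F)(F)F)cc2)s1`: 7.99 ug/mL
compound 3, `CN(C(=O)NC(=O)c1cccc(C(F)(F)F)c1)c1nc(C(F)(F)F)c(C(=O)N/N=C/c2ccc(C(F)(F)F)cc2)s1`: 7.35 ug/mL

In a functional assay on HeLa cells (Homo sapiens) for inhibition, read by MTT assay, with a stated time of 72 h (a lower number here means a stronger inhibitor, a higher number a weaker inhibitor), compound 1 stands highest of the three numbers, yet its neighbours lie close: the nearest is reached by a 1.2-fold lower number from compound 1 to compound 2 (0.08 log units; within the scatter), and compound 3, with 7.35 ug/mL, is within the scatter of compound 1 as well. The three measured compounds therefore give one level rather than a spread.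

Compound 4, `CN(C(=O)NC(=O)c1c(F)cccc1F)c1nc(C(F)(F)F)c(C(=O)N/N=C/c2cccc(C(F)(F)F)c2)s1`, differs from compound 1 in one place: 2,6-difluorophenyl in place of 2,4-dichlorophenyl on a carbonyl carbon. Within the data shown here, one measured step touches the same position on the shared core: there, exchanging the aryl group on the carbonyl carbon produced a 1.1-fold lower number from compound 2 to compound 3 (0.04 log units; within the scatter). The other step, on the aryl carbon double-bonded to nitrogen, was a 1.2-fold lower number from compound 1 to compound 2 (0.08 log units; within the scatter). Both leave the number unchanged beyond the scatter, and neither involves the 2,6-difluorophenyl group itself, so the evidence for this exact change is indirect. On that basis compound 4 is expected to land near compound 1, with a 1.1-fold lower number from compound 1 to compound 4 (0.03 log units; within the scatter), a step expected to stay within the scatter. The estimate for compound 4 is 9 ug/mL, between 4.5 ug/mL and 18 ug/mL.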

Compound 4, half-maximal inhibitory concentration: 21.6 ug/mL
The estimate for compound 4 lay 2.4-fold (0.38 log units) below the measured number, and the stated range ends below it.
By their numbers in this assay, from the lowest: compounds 3, 2 and 1 (each within the scatter of the next); then compound 4.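

In this assay, the aryl group on the carbonyl carbon can shift the number: 2,6-difluorophenyl in place of 2,4-dichlorophenyl gave a 2.3-fold higher number from compound 1 to compound 4 (0.35 log units; beyond the scatter), a modest step and the only one shown that lies beyond the scatter. The exchange at this position in the earlier pair, a 1.1-fold lower number from compound 2 to compound 3 (0.04 log units; within the scatter), stayed within the scatter, so this position does not treat all aryl groups alike, although that pair carries a different group on the carbon with a double bond to nitrogen. The leaving and entering groups match in their counts of heavy atoms, donors and acceptors, and no measurement shown accounts for the higher number.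

This change alters both the halogen and its placement at once, so 2,4-difluorophenyl and 2,6-dichlorophenyl would be needed to separate the two. Also open, going by these compounds, are whether the step carries over to the background of compound 2, and how this position responds to a phenyl ring bearing an amine or a carboxylic acid.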